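A Methoxy-to-Phenyl Swap Carried Across Two Related Cores

This account rests on a few compounds, and the source may have more. Where it says the series, first, only, none or still open, it means among the compounds named here.

Compound 1 `COc1ccc(NC(=O)COc2c(-c3ccccc3)oc3ccccc3c2=O)cc1` and compound 3 `COc1ccc(NC(=O)COc2ccc3oc(-c4ccccc4)cc(=O)c3c2)cc1` are built from the same atoms joined differently; the difference between their two cores is not broken down here. In a functional assay on NCI-H661 cells (Homo sapiens) for antiproliferative activity, read by MTT assay, with a stated time of 72 h (on this read-out lower numbers stand for stronger inhibition of growth and higher numbers for weaker inhibition of growth), compound 1 gives 6740 nM. In this assay compound 3 gives 840 nM, the lowest of the two numbers and beyond the scatter from compound 1. Compound 2 `O=C(COc1c(-c2ccccc2)oc2ccccc2c1=O)Nc1ccc(-c2ccccc2)cc1` differs from compound 1 by phenyl in place of methoxy on an aromatic carbon. For compound 2 this assay reports only a limit, > 10000 nM. The resulting step is an at least 1.4-fold higher number from compound 1 to compound 2 (0.17 log units; that floor lies within the scatter), and its floor is set because one of the three values sits at the limit of > 10000 nM in this assay, at which 1 of the 3 values shown sits.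

Compound 4 `O=C(COc1ccc2oc(-c3ccccc3)cc(=O)c2c1)Nc1ccc(-c2ccccc2)cc1` has not yet been measured. It differs from compound 3 by phenyl in place of methoxy on an aromatic carbon, the same change that separates compound 1 from compound 2, made at a place described in the same words. For compound 4 the expected step is a 3.0-fold higher number from compound 3 to compound 4 (0.47 log units; beyond the scatter), resting on an at least 1.4-fold higher number from compound 1 to compound 2 (0.17 log units; that floor lies within the scatter). In this assay compound 4 is estimated at 2500 nM, between 1000 nM and 8000 nM.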

Compound 4, concentration for 50% growth inhibition: 9710 nM
Estimate against measurement, compound 4: 3.9-fold (0.59 log units) below, and the stated range ends below it.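

On the core of compound 3, phenyl in place of methoxy on an aromatic carbon gives a 12-fold higher number from compound 3 to compound 4 (1.06 log units; beyond the scatter) in this assay, a clear loss of growth inhibition. Set beside the same change on the core of compound 1, the two steps compare as follows: the same change on two cores in this assay, an at least 1.4-fold higher number (0.17 log units; that floor lies within the scatter) from compound 1 to compound 2 and a 12-fold higher number (1.06 log units; beyond the scatter) from compound 3 to compound 4; the limit leaves it open whether they differ. The series therefore shows a step beyond the scatter on one core only, and it shows neither that the change carries over between the cores at the same size nor that its size depends on the core, since the value of compound 2 is a limit and not a number: the limit of > 10000 nM in this assay, at which 1 of the 4 values shown sits.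

The compounds shown leave open how other groups on this aromatic carbon would read on either core, such as a fluorine atom, a hydroxyl or an amine. They also leave open whether a carboxylic acid on that ring, or a longer chain in place of the linking amide chain, would change the picture.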